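The source may hold more compounds than are shown below. What is called first, only, known or untested is meant among the compounds shown, and "the series" means these compounds.

Compound 1 `COc1cc(-c2nc(-c3ccccc3)[nH]c2-c2ccnc(NCCCNS(=O)(=O)c3ccccc3)n2)ccc1F` carries a 4-fluoro-3-methoxyphenyl group on the shared core and a (phenylsulfonyl)amino end on its chain. In a functional assay on LOX IMVI cells (Homo sapiens) for cytotoxicity, read by MTT assay, with a stated time of 24 h (on this read-out lower numbers stand for stronger inhibition and higher numbers for weaker inhibition), compound 1 gives 4520 nM. Compound 2 `COc1cc(-c2nc(-c3ccccc3)[nH]c2-c2ccnc(NCCCNS(=O)(=O)c3ccc(Cl)cc3)n2)ccc1F` differs from it by chloro in place of hydrogen on an aromatic carbon, and in this assay compound 2 gives 83100 nM, a move of an 18-fold higher number from compound 1 to compound 2 (1.26 log units; beyond the scatter). Compound 3 `O=S(=O)(NCCCNc1nccc(-c2[nH]c(-c3ccccc3)nc2-c2ccc(Cl)c(O)c2)n1)c1ccccc1` keeps the (phenylsulfonyl)amino end, while its core differs from that of compound 1 by 4-chloro-3-hydroxyphenyl in place of 4-fluoro-3-methoxyphenyl on an aromatic carbon; in this assay compound 3 gives 2630 nM, which is a 1.7-fold lower number from compound 1 to compound 3 (0.24 log units; within the scatter). Compound 3 has the lowest of the three numbers, but its gap to compound 1 lies within the scatter, so no order between those two can be read; only compound 2 stands apart.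

Compound 4 `O=S(=O)(NCCCNc1nccc(-c2[nH]c(-c3ccccc3)nc2-c2ccc(Cl)c(O)c2)n1)c1ccc(Cl)cc1` has not yet been measured. It differs from compound 3 by chloro in place of hydrogen on an aromatic carbon. This is the same change as that made from compound 1 to compound 2: the two place descriptions agree word for word, on an aromatic carbon of a six-membered aromatic ring of carbon only, para to a large group. In the earlier pair the change brought an 18-fold higher number from compound 1 to compound 2 (1.26 log units; beyond the scatter). Among the measured compounds shown here, because that step of an 18-fold higher number from compound 1 to compound 2 (1.26 log units; beyond the scatter) was large and beyond the scatter, one expects a step of similar size for compound 4, a 16-fold higher number from compound 3 to compound 4 (1.20 log units; beyond the scatter), while noting that only one such pair is at hand and that the core is not the same. Compound 4 is therefore estimated to give 42000 nM in this assay, with a range from 9000 nM to 150000 nM.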

Compound 4, half-maximal inhibitory concentration: 61300 nM
Estimate against measurement, compound 4: 1.5-fold (0.16 log units) below, and the stated range covers the measured number.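

In this assay, chloro in place of hydrogen on an aromatic carbon again gives a large step on the second core, a 23-fold higher number from compound 3 to compound 4 (1.37 log units; beyond the scatter), and the two steps agree, so on these two cores the change carries over with its size intact: the same change on two cores in this assay, an 18-fold higher number (1.26 log units; beyond the scatter) from compound 1 to compound 2 and a 23-fold higher number (1.37 log units; beyond the scatter) from compound 3 to compound 4, 1.3-fold (0.10 log units) apart, within the scatter of two such steps. The exchange of 4-fluoro-3-methoxyphenyl for 4-chloro-3-hydroxyphenyl stays within the scatter when the chloro is present, a 1.4-fold lower number from compound 2 to compound 4 (0.13 log units; within the scatter), as it does when the chloro is absent, so neither pair gives a readable order between the two cores: the same change on two cores in this assay, a 1.7-fold lower number (0.24 log units; within the scatter) from compound 1 to compound 3 and a 1.4-fold lower number (0.13 log units; within the scatter) from compound 2 to compound 4, 1.3-fold (0.10 log units) apart, within the scatter of two such steps. This rests on just two pairs of compounds, one substituent in one place and one assay, so it does not show that the step would hold on other cores, and it says nothing about why the chloro has so large an effect on the number.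

The compounds shown leave open whether fluoro, methoxy or trifluoromethyl in place of the chloro on the phenylsulfonyl group would bring a step of similar size. They also leave open whether the step survives with a longer chain, or with an amide or a simple amine in place of the sulfonamide end.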